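The source may hold more compounds than are shown below. What is called first, only, known or untested is meant among the compounds shown, and "the series" means these compounds.

Three compounds have been measured in an assay on microsomes from liver for inhibition of 3-hydroxy-3-methylglutaryl-coenzyme A reductase (Rattus norvegicus), read by scintillation counting, with stated times of 0.5 h and 0.75 h; on this read-out lower numbers stand for stronger inhibition and higher numbers for weaker inhibition:

Compound 1 `O=C(O)C[C@H](O)C[C@H](O)CCn1c(-c2ccc(F)cc2)nc(C(=O)NCc2ccccc2F)c1C1CC1` gives 1.5 nM.
Compound 2 `COc1ccc(CNC(=O)c2nc(-c3ccc(F)cc3)n(CC[C@@H](O)C[C@@H](O)CC(=O)O)c2C2CC2)cc1F` gives 3.7 nM.
Compound 3 `O=C(O)C[C@H](O)C[C@H](O)CCn1c(-c2ccc(F)cc2)nc(C(=O)NCc2cccc(F)c2)c1C1CC1` gives 1.2 nM.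

Among these three numbers compound 1 stands second highest: its nearest neighbour is compound 3, with a 1.3-fold lower number from compound 1 to compound 3 (0.10 log units; within the scatter), a gap within the scatter, while compound 2 lies furthest, with a 2.5-fold higher number from compound 1 to compound 2 (0.39 log units; beyond the scatter). Compound 4 `O=C(O)C[C@H](O)C[C@H](O)CCn1c(-c2ccc(F)cc2)nc(C(=O)NCc2ccccc2)c1C1CC1` is not yet measured. It differs from compound 1 in one place: hydrogen in place of fluoro on an aromatic carbon, that is, 2-fluorobenzyl to benzyl. Going by the values given here, no measured step removes a fluoro from this ring outright. Among the compounds with values here, the closest guide is the move of the fluoro from one ring position to another, a 1.3-fold lower number from compound 1 to compound 3 (0.10 log units; within the scatter), which stays within the scatter; the only step beyond the scatter on this benzyl group, a 3.1-fold lower number from compound 2 to compound 3 (0.49 log units; beyond the scatter), concerns a methoxy and not a fluoro. The expectation for this assay is therefore a step of no size beyond the scatter, a 1.2-fold higher number from compound 1 to compound 4 (0.08 log units; within the scatter). Compound 4 is estimated at 1.8 nM, with a range from 0.9 nM to 3.6 nM.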

Compound 4, half-maximal inhibitory concentration: 1.4 nM
For compound 4 the middle estimate is 1.3-fold (0.11 log units) above the measured one, within the range that was stated.
By their numbers in this assay, from the lowest: compounds 3, 4 and 1 (each within the scatter of the next); then compound 2.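

In this assay, taking the fluoro off the ring altogether gives no step beyond the scatter, whichever of the two fluoro compounds serves as the starting point: a 1.1-fold lower number from compound 1 to compound 4 (0.03 log units; within the scatter), and a 1.2-fold higher number from compound 3 to compound 4 (0.07 log units; within the scatter). The fluoro itself therefore adds nothing measurable here, something the earlier move of the fluoro around the ring could not show, while the bare phenyl ring keeps the group's one clear gap to the fluoro and methoxy ring, a 2.6-fold lower number from compound 2 to compound 4 (0.42 log units; beyond the scatter). No measurement is at hand that would explain why this change is so well tolerated.

The compounds shown leave open whether a methoxy alone on this ring would give the same gap as the fluoro and methoxy pair. They also leave open how a chloro, an amine or a longer chain in place of the benzyl group would read.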